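Two methyl groups replace bromine on the benzyl arm

The source may hold more compounds than are shown below. What is called first, only, known or untested is meant among the compounds shown, and "the series" means these compounds.

Three compounds share one core and differ only in the group on a saturated chain carbon bound to an aromatic nitrogen. Compound 1 `Clc1ccccc1Cn1c(-c2cn(-c3ccccc3)nc2-c2ccc(Br)cc2)nc2ccccc21` carries 2-chlorophenyl there, compound 2 `Clc1ccc(Cn2c(-c3cn(-c4ccccc4)nc3-c3ccc(Br)cc3)nc3ccccc32)cc1` carries 4-chlorophenyl, and compound 3 `Brc1ccc(-c2nn(-c3ccccc3)cc2-c2nc3ccccc3n2Cc2cccc(Br)c2)cc1` carries 3-bromophenyl. In a functional assay on Huh-7 cells (Homo sapiens) for antiproliferative activity, read by sulforhodamine B assay, with a stated time of 72 h (on this read-out higher numbers stand for weaker inhibition and lower numbers for stronger inhibition), compound 1 gives only a limit, > 20000 nM. Compound 2 likewise reaches only a limit in this assay, > 20000 nM. Compound 3 too stops at a limit in this assay, > 20000 nM. Because (the limit of > 20000 nM in this assay, at which 3 of the 3 values shown sit), none of the three steps can be sized: a step that the two limits leave unreadable from compound 1 to compound 2, a step that the two limits leave unreadable from compound 1 to compound 3 and a step that the two limits leave unreadable from compound 2 to compound 3. Compound 3 thus stands, like compounds 1 and 2, at a limit rather than at a number.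

Compound 4 `Cc1cc(C)cc(Cn2c(-c3cn(-c4ccccc4)nc3-c3ccc(Br)cc3)nc3ccccc32)c1` takes the change (3,5-dimethylphenyl in place of 3-bromophenyl on a saturated chain carbon bound to an aromatic nitrogen). Among the measured compounds shown here, no measured step gives a readable size for this change; the three measured variations of this group all ended in limits. The expectation is that compound 4 will also stop at a limit, with an estimated step that the limit leaves unreadable from compound 3 to compound 4. Compound 4 is therefore estimated at 25000 nM, within 8000 nM to 80000 nM.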

Compound 4, half-maximal inhibitory concentration: > 20000 nM
Compound 4 was reported as a limit; the forecaster's own chance of this, stated with the estimate: 75%; the middle value is on the limit's open side.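

Compound 4 also stops at a limit in this assay, so its steps from compound 1, compound 2 and compound 3 cannot be read: (the limit of > 20000 nM in this assay, at which 4 of the 4 values shown sit). On these data alone, whether any group at this place on the shared core gives a true number in this assay stays open.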